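Compound 4: A Chlorodifluorophenyl Amide Expected to Fall Back

The source may report more compounds than this note shows. Statements on the series, on what has been measured and on what is new or still open speak of the compounds shown alone.

Measured compounds:
compound 1, `O=C(Nc1ccc(S(=O)(=O)Nc2ccccc2)cc1)c1ccc(Br)cc1F`, 67%
compound 2, `Cc1cc(Cl)ccc1C(=O)Nc1ccc(S(=O)(=O)Nc2ccccc2)cc1`, 123%
compound 3, `Cc1cc(Br)ccc1C(=O)Nc1ccc(S(=O)(=O)Nc2ccccc2)cc1`, 103%

All three share one core, an anilide carrying a sulfonamide, and differ only in the aryl group on the carbonyl carbon. In a functional assay on HEK293 cells for agonist activity at probable G-protein coupled receptor 27 (Homo sapiens), read by a luciferase reporter and beta-arrestin recruitment, with a stated time of 10 min (on this read-out lower numbers stand for smaller maximal responses and higher numbers for larger maximal responses), compound 3 stands second highest of the three numbers. Its nearest neighbour is compound 2, with a number 20 percentage points lower from compound 2 to compound 3 (beyond the scatter). Its furthest is compound 1, with a number 36 percentage points higher from compound 1 to compound 3 (beyond the scatter). The step from compound 1 to compound 2, a number 56 percentage points higher from compound 1 to compound 2 (beyond the scatter), spans both changes at once.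

Compound 4, `O=C(Nc1ccc(S(=O)(=O)Nc2ccccc2)cc1)c1cc(F)c(Cl)cc1F`, is not yet measured. The change from compound 3 is 4-chloro-2,5-difluorophenyl in place of 4-bromo-2-methylphenyl on a carbonyl carbon. Among the measured compounds shown here, two measured steps bear on it. The step from compound 1 to compound 3 shows what methyl in place of fluoro did; compound 4 reverses that, so a drop is expected. The step from compound 2 to compound 3 shows chloro outperforming bromo; compound 4 gains chloro, which should recover part of the loss. For the measured compounds named here, the second fluoro has no measured counterpart. On balance compound 4 is expected to fall below compound 3, with a number 25 percentage points lower from compound 3 to compound 4 (beyond the scatter). Compound 4 is estimated at 78%, in a range from 55% to 100%.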

Compound 4, largest response reached (Emax), in percent of the reference or control that the assay uses: 37%
For compound 4 the middle estimate is 41 percentage points above the measured one; the whole stated range lies above it.
By their numbers in this assay, from the lowest: compound 4; then compound 1; then compound 3; then compound 2.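

Compound 4 is the lowest of the four in this assay, and the change on the carbonyl carbon gives a number 66 percentage points lower from compound 3 to compound 4 (beyond the scatter) and, with the chloro kept, a number 86 percentage points lower from compound 2 to compound 4 (beyond the scatter), so a 4-chloro aryl group does not by itself sustain a large maximal response. Compared with compound 1, which also carries fluoro on its aryl group, 4-chloro-2,5-difluorophenyl gives a number 30 percentage points lower from compound 1 to compound 4 (beyond the scatter), which shows that this position can take the response well below the level of the earlier fluoro compound and not only below that of the two methyl compounds. No available evidence explains this fall.

The compounds shown leave open how much of the loss goes with the absence of the methyl and how much with the second fluoro, since the two changes arrive together in compound 4. They also leave open how the response at this position would behave with a methoxy group or an amine on the aryl ring in place of these halogens.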